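The source may report more compounds than this note shows. Statements on the series, on what has been measured and on what is new or still open speak of the compounds shown alone.

Compound 1 `O=C(/C=C/c1ccc(Br)cc1)c1ccccc1O` and compound 3 `O=C(/C=C/c1ccc(Cl)cc1)c1ccccc1O` share one core, while compound 2 `O=C(/C=C/c1cccc(Br)c1)c1ccccc1O` is built from the same atoms joined differently; the difference between the two cores is not broken down here. In a functional assay on HCT-116 cells (Homo sapiens) for cytotoxicity, read by MTT assay, with a stated time of 48 h (a higher number here means a weaker inhibitor, a lower number a stronger inhibitor), compound 1 gives 19100 nM. In this assay compound 3 gives 20900 nM. In this assay compound 2 gives 10900 nM. Among the compounds with values here, the only single-point step among the measured compounds is a 1.1-fold higher number from compound 1 to compound 3 (0.04 log units; within the scatter), produced by the change (chloro in place of bromo on an aromatic carbon).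

Compound 4 `O=C(/C=C/c1cccc(Cl)c1)c1ccccc1O` has not yet been measured. It differs from compound 2 by chloro in place of bromo on an aromatic carbon. Within the data shown here, this is the same kind of change as the one made from compound 1 to compound 3, not the same change: in compound 3 the chloro sits para to a large group, whereas in compound 4 it sits meta to a large group. Among the measured compounds shown here, because the only precedent is the step of a 1.1-fold higher number from compound 1 to compound 3 (0.04 log units; within the scatter), the expected step is a 1.1-fold higher number from compound 2 to compound 4 (0.04 log units; within the scatter), resting on that single example. For compound 4 the estimate in this assay is 12000 nM, expected to fall between 6000 nM and 24000 nM.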

Compound 4, half-maximal inhibitory concentration: 13200 nM
Beside the measured number, compound 4's estimate is 1.1-fold (0.04 log units) below it, within the range that was stated.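

In this assay, chloro in place of bromo on an aromatic carbon gives a 1.2-fold higher number from compound 2 to compound 4 (0.08 log units; within the scatter). Set beside the earlier step, the change carries from one core to the other with no difference that these data can separate: the same change on two cores in this assay, a 1.1-fold higher number (0.04 log units; within the scatter) from compound 1 to compound 3 and a 1.2-fold higher number (0.08 log units; within the scatter) from compound 2 to compound 4, 1.1-fold (0.04 log units) apart, within the scatter of two such steps. This does not show that the change would carry to any core beyond these two, and with both steps within the scatter, the agreement is one between two small steps rather than a test of whether a large effect would carry over.

The compounds shown hold only bromo or chloro as the group on that aromatic carbon, so they say nothing about a smaller or a larger replacement. Open questions are how fluoro, a methoxy group, an amine or a carboxylic acid on that carbon would read in this assay, and whether such a group would give the same step on both cores.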